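Methoxy for methyl beside a trifluoromethyl group

A few compounds are considered here, and "the series" means these few. Any claim that something is new, unique, unknown or untested is made for them only; others in the source may bear on it.

Compound 1 `Cc1ccc(-c2cn(-c3ccc(CN4CCCC4)cc3)nn2)cc1Nc1nccc(-c2cccnc2)n1`: 5420 nM
Compound 2 `Cc1ccc(-n2cc(-c3ccc(CN4CCN(C)CC4)c(C(F)(F)F)c3)nn2)cc1Nc1nccc(-c2cccnc2)n1`: 1270 nM
Compound 3 `Cc1ccc(-n2cc(-c3ccc(C)c(C(F)(F)F)c3)nn2)cc1Nc1nccc(-c2cccnc2)n1`: > 30000 nM

In a functional assay on KG-1a cells (Homo sapiens) for inhibition, read by MTT assay, with a stated time of 72 h (on this read-out lower numbers stand for stronger inhibition and higher numbers for weaker inhibition), compound 1 gives 5420 nM and compound 2 gives 1270 nM. For compound 3 the assay reports only a limit, > 30000 nM; that is the limit of > 30000 nM in this assay, at which 1 of the 3 values shown sits. Within the data shown here, compound 3 thus stands at the weak end of the values shown, and the one measured step, an at least 23-fold higher number from compound 2 to compound 3 (1.37 log units; beyond the scatter), ends there. Compound 4 `COc1ccc(-c2cn(-c3ccc(C)c(Nc4nccc(-c5cccnc5)n4)c3)nn2)cc1C(F)(F)F` differs from compound 3 by methoxy in place of methyl on an aromatic carbon. Among the measured compounds shown here, no measured step concerns this change; the step from compound 2 to compound 3 involved a different group and so does not bear on it. Compound 4 is therefore expected to stay near the limit, with a step of a number no higher from compound 3 to compound 4 (the limit leaves the size open) of no size beyond the scatter. The estimate for compound 4 in this assay is 30000 nM, between 10000 nM and 100000 nM.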

Compound 4, half-maximal inhibitory concentration: 30000 nM
Estimate against measurement, compound 4: no gap at the digits printed; measured number inside the range.
By their numbers in this assay, from the lowest: compound 2; then compound 1; then compound 4.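

In this assay, methoxy on this aromatic carbon, in place of (4-methylpiperazin-1-yl)methyl, gives a 24-fold higher number from compound 2 to compound 4 (1.37 log units; beyond the scatter), so the loss of that group now shows against a measured number and not only against a limit. Compound 3 has only a limit, > 30000 nM. Methoxy in place of methyl gives a number no higher from compound 3 to compound 4 (the limit leaves the size open), and the size of this step therefore cannot be read: the limit of > 30000 nM in this assay, at which 1 of the 4 values shown sits.

The compounds shown leave open whether a morpholine, a primary amine or a carboxylic acid on this carbon would bring the number back towards that of compound 2. They also leave open what a longer chain carrying the 4-methylpiperazin-1-yl group would do.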